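The source may report more compounds than this note shows. Statements on the series, on what has been measured and on what is new or still open speak of the compounds shown alone.

Measured compounds:
- compound 1, `CC(=O)N(C)c1ccc2c(c1)CCN2c1cc(OC2CCN(c3nc(C(C)C)no3)CC2)ncn1`: 3.7
- compound 2, `CC(C)SC(=O)N1CCC(Oc2cc(N3CCc4cc(S(C)(=O)=O)ccc43)ncn2)CC1`: 3.6
- compound 3, `CC(C)OC(=O)N1CCC(Oc2cc(N3CCc4cc(S(C)(=O)=O)ccc43)ncn2)CC1`: 3.1

The values come from a physicochemical assay for lipophilicity, measured as octanol-water partition, at pH 7.4; a higher number here means a more lipophilic compound, a lower number a more polar compound. Compound 1 has the highest of the three numbers, though the gap to compound 2 lies within the scatter, while the gap to compound 3 lies beyond it. Among the measured compounds shown here, the only step between compounds that differ in one place is a number 0.50 log units lower from compound 2 to compound 3 (beyond the scatter), a change on a carbonyl carbon that sits far from the site altered here.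

Compound 4, `CC(C)c1noc(N2CCC(Oc3cc(N4CCc5cc(N6CCCNS6(=O)=O)ccc54)ncn3)CC2)n1`, is not yet measured in this assay. It differs from compound 1 in one place: a group of 8 heavy atoms (3 carbon, 2 nitrogen, 2 oxygen, 1 sulfur; one six-membered non-aromatic ring with 3 hetero atoms) in place of a group of 5 heavy atoms (3 carbon, 1 nitrogen, 1 oxygen; no ring), on an aromatic carbon The change replaces a group with no hydrogen-bond donor by a ring-bearing group that carries one hydrogen-bond donor and two acceptors. For the measured compounds named here, no measured step covers this exchange; compounds 2 and 3 carry yet another group in the same place but also differ elsewhere, so they give no direct guide. A moderate decrease is nonetheless expected, a number 0.70 log units lower from compound 1 to compound 4 (beyond the scatter), and compound 4 is estimated at 3, between 2.4 and 3.6.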

Compound 4, distribution coefficient: 3.2
Beside the measured number, compound 4's estimate is 0.20 log units below it; the range from low to high includes it.
By their numbers in this assay, from the lowest: compounds 3 and 4 (each within the scatter of the next); then compounds 2 and 1 (each within the scatter of the next).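

At this aromatic carbon, meta to a fused ring and para to a fused ring, replacing acetyl(methyl)amino with the six-membered ring with 3 hetero atoms gives, in this assay, a number 0.50 log units lower from compound 1 to compound 4 (beyond the scatter). Among the compounds shown here, this is the first direct comparison at this position, and it shows that a change here alone can move the reading beyond the scatter. The exchange alters the ring count, size, and hydrogen-bond donors and acceptors together, and no measurement is available to explain the shift.

The compounds shown cannot separate these features from one another. A version of the same ring with a methyl group on its donor nitrogen, or a morpholine ring on this aromatic carbon, would be needed to test them apart.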